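Imidazolyl in place of phenylsulfanyl on a shared core

The source may hold more compounds than are shown below. What is called first, only, known or untested is meant among the compounds shown, and "the series" means these compounds.

compound 1 `Cc1c(N)c(C)c2c(c1CC(C)C)OC(C)(C)C2` — 13.3 mg/kg
compound 2 `Cc1c(C)c2c(c(C)c1N)CC(C)(CSc1ccccc1)O2` — 24.7 mg/kg

In a functional assay on the whole organism with Mus musculus as the target (a higher number here means that more compound is needed for the effect, a lower number that less compound is needed), compound 2 holds the higher of the two numbers shown, yet compound 1 sits within the scatter of it, so the pair cannot be ordered. Compound 3 `Cc1c(C)c2c(c(C)c1N)CC(C)(Cn1ccnc1)O2` differs from compound 2 by 1H-imidazol-1-yl in place of phenylsulfanyl on a saturated chain carbon bound to a saturated ring carbon. Among the measured compounds shown here, no measured pair shows how such a change bears on this assay, and with only two compounds measured, no step beyond the scatter is expected. Compound 3 is estimated at 25 mg/kg, between 10 mg/kg and 60 mg/kg. The expected step of a 1.0-fold higher number from compound 2 to compound 3 (0.01 log units; within the scatter) is thus estimated to remain within the scatter.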

Compound 3, dose for 50% inhibition: 25 mg/kg
Compound 3: the middle estimate sits on the measured number at the digits printed; low and high end bracket the measured number.
By their numbers in this assay, from the lowest: compounds 1, 2 and 3 (each within the scatter of the next).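

In this assay, among the compounds shown here, the exchange of phenylsulfanyl for 1H-imidazol-1-yl on a saturated chain carbon bound to a saturated ring carbon gives a 1.0-fold higher number from compound 2 to compound 3 (0.01 log units; within the scatter) and is the only step that can be read here. At this place, then, a five-membered aromatic ring with two hetero atoms and a six-membered aromatic ring of carbon only cannot be told apart in this measurement. No available evidence accounts for this result. The compounds shown leave open whether an amine or a carboxylic acid on that chain carbon would also stay within the scatter of compound 2.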